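Amino series: piperidinyl to methylpiperazinyl at the chain carbon

The source may report more compounds than this note shows. Statements on the series, on what has been measured and on what is new or still open speak of the compounds shown alone.

In a functional assay on MDA-MB-231 cells (Homo sapiens) for antiproliferative activity, read by sulforhodamine B assay, with a stated time of 48 h, tested at 10 uM (on this read-out lower numbers stand for less inhibition and higher numbers for more inhibition at the one concentration tested (going by the name of the read-out)), compound 1 `CCCCCCCCCCCCCC[C@H](OCOC)[C@H](CO)NC(=O)OC(C)(C)C` gives -5.67%, and compound 2 `CCCCCCCCCCCCCC[C@H](OCOC)[C@H](CN1CCCCC1)NC(=O)OC(C)(C)C` gives 9.84%, the higher of the two numbers; the step of a number 15.5 percentage points higher from compound 1 to compound 2 (beyond the scatter) separates them. Compound 3 `CCCCCCCCCCCCCC[C@H](OCOC)[C@H](CN1CCN(C)CC1)NC(=O)OC(C)(C)C` is not yet measured; it differs from compound 2 by 4-methylpiperazin-1-yl in place of piperidin-1-yl on a saturated chain carbon, two bonds along the chain from an amide-type nitrogen. No measured step exchanges one such ring for another, so the one step shown bears only loosely on this change. No step beyond the scatter is expected for compound 3 in this assay, and the expected value is 12% with a range of -8% to 32%. The expected step is a number 2.2 percentage points higher from compound 2 to compound 3 (within the scatter).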

Compound 3, a percentage reported as inhibition, at one concentration (the size of the read-out at that concentration, not a potency): 24%
Beside the measured number, compound 3's estimate is 12 percentage points below it, and the stated range covers the measured number.
By their numbers in this assay, from the lowest: compound 1; then compound 2; then compound 3.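

In this assay, the identity of the ring on this saturated chain carbon, two bonds along the chain from an amide-type nitrogen, matters in its own right: 4-methylpiperazin-1-yl in place of piperidin-1-yl gives a number 14.2 percentage points higher from compound 2 to compound 3 (beyond the scatter). Going by these compounds alone, replacing the hydroxy group with 4-methylpiperazin-1-yl gives a number 29.7 percentage points higher from compound 1 to compound 3 (beyond the scatter), the largest step so far. No evidence on hand accounts for the gain.

Open, going by these compounds, is whether the gain tracks the second ring nitrogen or its methyl group, which piperazin-1-yl and morpholin-4-yl at this carbon would separate. Also open, on these data alone, is how the ring behaves with a free amine in place of the tert-butyl carbamate.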